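Halogen swap on the benzylamide of a succinimide series

A few compounds are considered here, and "the series" means these few. Any claim that something is new, unique, unknown or untested is made for them only; others in the source may bear on it.

Measured so far:
compound 1 `CC(C(=O)NCc1cccc(Cl)c1)N1C(=O)CCC1=O` — "not determined" (no result reported)
compound 2 `CCC(C(=O)NCc1cccc(Cl)c1)N1C(=O)CCC1=O` — 78.9 mg/kg

Among the compounds with values here, in a functional assay on the whole organism (strain Albino Swiss CD1) with Mus musculus as the target (on this read-out higher numbers stand for an effect only at larger amounts of compound and lower numbers for an effect already at smaller amounts), compound 2 gives 78.9 mg/kg and is the only number in hand, as compound 1 has no result. Compound 3 `CCC(C(=O)NCc1ccc(F)cc1)N1C(=O)CCC1=O` carries 4-fluorophenyl in place of 3-chlorophenyl on a saturated chain carbon bound to an amide-type nitrogen. With no measured step on this change, nothing shown points in either direction, so the step in this assay is expected to stay within the usual scatter. The estimate for compound 3 is 80 mg/kg (range 35 mg/kg to 180 mg/kg), meaning an expected step of a 1.0-fold higher number from compound 2 to compound 3 (0.01 log units; within the scatter).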

Compound 3, dose for half-maximal effect: 83.4 mg/kg
The estimate for compound 3 lay 1.0-fold (0.02 log units) below the measured number; the range from low to high includes it.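

In this assay, 4-fluorophenyl in place of 3-chlorophenyl gives a 1.1-fold higher number from compound 2 to compound 3 (0.02 log units; within the scatter). Within the data shown here, this is the first measured step at this position, and it shows that this swap leaves the two compounds indistinguishable on this read-out. No other measurement here bears on this result.

The halogen and its place on the ring change together in this step, so the compounds shown cannot separate the two. On these data alone, how an amine or a carboxylic acid on the ring would read in this assay also remains open.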